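Bromo-fluorophenyl variant of a diarylidene piperazinedione

The source may report more compounds than this note shows. Statements on the series, on what has been measured and on what is new or still open speak of the compounds shown alone.

For the measured compounds named here, compound 1 `C=CCn1c(=O)/c(=C\c2cccc(F)c2)[nH]c(=O)/c1=C\c1ccccc1OC` is the only member of the series with a number: in a functional assay on MOLT-4 cells (Homo sapiens) for cytotoxicity, read by CCK-8 assay, with a stated time of 72 h (on this read-out higher numbers stand for weaker inhibition and lower numbers for stronger inhibition), compound 1 gives 6500 nM. Going by the values given here, compound 2 `C=CCn1c(=O)/c(=C\c2cc(OC)c(OC)c(OC)c2)[nH]c(=O)/c1=C\c1cccc(Br)c1` was reported in this assay as "not active" (no number reported), and compound 3 `COc1ccccc1/C=c1/[nH]c(=O)/c(=C\c2nc[nH]c2C(C)(C)C)[nH]c1=O` as "not determined" (no result reported), so neither offers a comparison point, and no single-change step between measured compounds is available. Compound 4 `C=CCn1c(=O)/c(=C\c2cc(Br)ccc2F)[nH]c(=O)/c1=C\c1ccccc1OC` differs from compound 1 by 5-bromo-2-fluorophenyl in place of 3-fluorophenyl on a double-bonded chain carbon bound to an aromatic carbon. Among the compounds with values here, with no step of this kind on record, the change is expected to stay close to the scatter, with a slight lean toward weaker inhibition; the step from compound 1 to compound 4 is estimated at a 1.2-fold higher number from compound 1 to compound 4 (0.09 log units; within the scatter). Compound 4 is therefore expected to give about 8000 nM, in a range from 2500 nM to 25000 nM.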

Compound 4, half-maximal inhibitory concentration: 12900 nM
Beside the measured number, compound 4's estimate is 1.6-fold (0.21 log units) below it; the measured number falls inside the stated range.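

In this assay, 5-bromo-2-fluorophenyl in place of 3-fluorophenyl on a double-bonded chain carbon bound to an aromatic carbon gives a 2.0-fold higher number from compound 1 to compound 4 (0.30 log units; within the scatter). For the compounds shown here, this is the first single-change reading, and it shows that this place accepts a ring carrying bromine as well as fluorine without a step beyond the scatter. No measured property is available to account for this step.

Still open, from the compounds shown here alone, is how an amine or a carboxylic acid on this ring would read. The compounds shown also do not separate the contribution of the bromine from that of the fluorine's placement.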